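Shortening the oxane linker in a chemokine receptor antagonist series

The compounds below may be only part of what the source reports. "The series", "measured", "known", "first", "only" and "open" are said of these compounds alone.

Compound 1, `c1ccc2c(c1)CN[C@@H](CN(CCCCNCc1ccncc1)[C@H]1CCCc3cccnc31)C2`, gives 22.7 nM in a functional assay on cells for antagonist activity at C-X-C chemokine receptor type 4 (Homo sapiens), read by fluorescence and calcium flux, with stated times of 25 min and 90 s; on this read-out lower numbers stand for stronger inhibition and higher numbers for weaker inhibition.
Compound 2, `c1ccc2c(c1)CN[C@@H](CN(CCCCNCC1CCOCC1)[C@H]1CCCc3cccnc31)C2`, gives 52.9 nM in this assay.
Compound 3, `CC(C)(CCN(C[C@H]1Cc2ccccc2CN1)[C@H]1CCCc2cccnc21)CNCC1CCOCC1`, gives 43.8 nM in this assay.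

Compound 3 stands second highest of these three numbers; its nearest neighbour is compound 2 (a 1.2-fold lower number from compound 2 to compound 3 (0.08 log units; within the scatter)), and compound 1 lies furthest (a 1.9-fold higher number from compound 1 to compound 3 (0.29 log units; within the scatter)). Compound 4, `CC(C)(CCN(C[C@H]1Cc2ccccc2CN1)[C@H]1CCCc2cccnc21)CNC1CCOCC1`, differs from compound 3 by oxan-4-yl in place of (oxan-4-yl)methyl on an amine nitrogen. Within the data shown here, none of the measured steps touches this amine substituent directly: the steps of a 2.3-fold higher number from compound 1 to compound 2 (0.37 log units; beyond the scatter) and a 1.9-fold higher number from compound 1 to compound 3 (0.29 log units; within the scatter) swap the ring or the chain and are small. By analogy, the step from compound 3 to compound 4 is expected to be small, a 1.4-fold higher number from compound 3 to compound 4 (0.14 log units; within the scatter), in this assay. Compound 4 is therefore estimated at 60 nM, with a range from 25 nM to 150 nM.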

Compound 4, half-maximal inhibitory concentration: 36.3 nM
The estimate for compound 4 lay 1.7-fold (0.22 log units) above the measured number; the range from low to high includes it.
By their numbers in this assay, from the lowest: compounds 1, 4, 3 and 2 (each within the scatter of the next, the first and the last beyond it).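

In this assay, oxan-4-yl in place of (oxan-4-yl)methyl on the amine nitrogen gives a 1.2-fold lower number from compound 3 to compound 4 (0.08 log units; within the scatter), so at this position the ring can sit directly on the nitrogen with no change beyond the scatter. The other comparisons also stay within it, with a 1.5-fold lower number from compound 2 to compound 4 (0.16 log units; within the scatter) and a 1.6-fold higher number from compound 1 to compound 4 (0.20 log units; within the scatter). No evidence is available on why this change leaves the number within the scatter.

The compounds shown leave open how a cyclohexyl or piperidin-4-yl group on this amine nitrogen, or a longer chain leading to the oxane ring, would read in this assay.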